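The compounds below may be only part of what the source reports. "The series", "measured", "known", "first", "only" and "open" are said of these compounds alone.

Three compounds have so far been measured in an assay on cells (Hepatocyte) for inhibition of glucokinase regulatory protein (Mus musculus), with stated times of 20 min and 40 min; on this read-out lower numbers stand for an effect already at smaller amounts and higher numbers for an effect only at larger amounts of compound:
compound 1 `CC#C[C@H]1CN(S(=O)(=O)c2ccc(N)nc2)CCN1c1ccc(S(N)(=O)=O)cc1` gives 37 nM;
compound 2 `CC#C[C@H]1CN(S(=O)(=O)c2ccc(N)nc2)CCN1c1ccc(C(O)(COC)C(F)(F)F)cc1` gives 202 nM;
compound 3 `CC#C[C@H]1CN(S(=O)(=O)c2ccc(N)nc2)CCN1c1ccc(C(O)(CC#N)C(F)(F)F)cc1` gives 219 nM.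

Among these three, compound 1 stands lowest in this assay. Its nearest neighbour is compound 2, with a 5.5-fold higher number from compound 1 to compound 2 (0.74 log units; beyond the scatter), and compound 3 lies furthest away, with a 5.9-fold higher number from compound 1 to compound 3 (0.77 log units; beyond the scatter). Compound 4 `CC#C[C@H]1CN(S(=O)(=O)c2ccc(N)nc2)CCN1c1ccc([C@](O)(CO)C(F)(F)F)cc1` has not yet been measured. It differs from compound 1 by 1,2-dihydroxy-1-(trifluoromethyl)ethyl in place of sulfamoyl on an aromatic carbon. The two measured steps that bear on this are of the same kind: in compound 2 and compound 3 the sulfamoyl likewise gives way to a larger group on that aromatic carbon, and in both cases the number rose by a modest but clear margin, as the steps just quoted show. Between compound 2 and compound 3 themselves, cyano in place of methoxy on the saturated chain carbon left the number essentially where it was, a 1.1-fold higher number from compound 2 to compound 3 (0.04 log units; within the scatter). On these two compounds, what sits on the chain made little difference, while the departure of sulfamoyl was what raised the number. For compound 4 the expected outcome is therefore a rise of about the same size, a 4.9-fold higher number from compound 1 to compound 4 (0.69 log units; beyond the scatter). Compound 4 is accordingly estimated at 180 nM, with a range from 70 nM to 450 nM.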

Compound 4, half-maximal effective concentration: 98 nM
The estimate for compound 4 lay 1.8-fold (0.26 log units) above the measured number; low and high end bracket the measured number.
By their numbers in this assay, from the lowest: compound 1; then compound 4; then compounds 2 and 3 (each within the scatter of the next).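

In this assay, the 1,2-dihydroxy-1-(trifluoromethyl)ethyl group also stands above sulfamoyl on this aromatic carbon, with a 2.6-fold higher number from compound 1 to compound 4 (0.42 log units; beyond the scatter) here, so all three replacements shown give higher numbers than compound 1, though the rise is not the same for each. The result also shows that the chain of the larger group can matter, which the match between the methoxy and cyano compounds had not revealed: there is a 2.2-fold lower number from compound 3 to compound 4 (0.35 log units; beyond the scatter) and a 2.1-fold lower number from compound 2 to compound 4 (0.31 log units; beyond the scatter) as well, and both steps lie beyond the scatter. Nothing shown here explains why these numbers differ.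

The compounds leave open how much of the lower number of compound 4 belongs to the hydroxyl on the chain and how much to its defined stereocentre, since compounds 2 and 3 are drawn without one and the opposite arrangement at that carbon is absent from this set. They also leave open whether an amine or a carboxylic acid on the same chain, or a longer chain, would bring the number closer to that of compound 1.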